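Aryl amide swap to trifluoromethyl-thiazole on the chromone series

The compounds below may be only part of what the source reports. "The series", "measured", "known", "first", "only" and "open" are said of these compounds alone.

Measured compounds:
compound 1 `CCCC(=O)Nc1cccc(NC(=O)COc2ccc3c(=O)ccoc3c2)c1` — in an assay on isolated protein for inhibition of Rho-associated protein kinase 1 (Homo sapiens), read by scintillation counting, radiometric assay and 33P incorporation, with a stated time of 40 min, in the presence of a further agent that is not named here (on this read-out higher numbers stand for weaker inhibition and lower numbers for stronger inhibition), compound 1 gives 1430 nM
compound 2 `Cc1cc(C(=O)Nc2cccc(NC(=O)COc3ccc4c(=O)ccoc4c3)c2)ccc1C(F)(F)F` — in this assay compound 2 gives 460 nM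

Among the compounds with values here, compound 2 holds the lowest number of the two measured; compound 1 is its only neighbour, with a 3.1-fold lower number from compound 1 to compound 2 (0.49 log units; beyond the scatter) separating them. Within the data shown here, that single step swaps a short chain for the six-membered aromatic ring on the carbonyl carbon and is the only comparison in hand.

Compound 3 `O=C(COc1ccc2c(=O)ccoc2c1)Nc1cccc(NC(=O)c2cnc(C(F)(F)F)s2)c1` keeps the shared core and the amide and changes only the ring on that carbonyl: a group of 9 heavy atoms (4 carbon, 1 nitrogen, 3 fluorine, 1 sulfur; one five-membered aromatic ring with 2 hetero atoms) in place of a group of 11 heavy atoms (8 carbon, 3 fluorine; one six-membered aromatic ring of carbon only), on a carbonyl carbon. Among the measured compounds shown here, no measured step compares one aromatic ring with another on this carbonyl, so the step from compound 1 to compound 2 bears only indirectly, by showing an aromatic amide tolerated there. No step beyond the scatter is expected; compound 3 is estimated near compound 2, as a 1.3-fold higher number from compound 2 to compound 3 (0.12 log units; within the scatter), at 600 nM with a range of 200 nM to 2000 nM.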

Compound 3, half-maximal inhibitory concentration: 160 nM
For compound 3 the middle estimate is 3.8-fold (0.57 log units) above the measured one, outside the stated range (below it).
By their numbers in this assay, from the lowest: compound 3; then compound 2; then compound 1.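

On the carbonyl carbon whose other neighbour is the amide-type nitrogen, this assay now separates two aromatic rings: 2-(trifluoromethyl)-1,3-thiazol-5-yl gives a 2.9-fold lower number from compound 2 to compound 3 (0.46 log units; beyond the scatter) in place of the six-membered aromatic ring of carbon only. The place therefore responds to the identity of the ring, and does not merely tolerate an aromatic amide. Against propyl, the same group gives an 8.9-fold lower number from compound 1 to compound 3 (0.95 log units; beyond the scatter) and sets the widest span yet seen at this place, though no evidence shown accounts for the difference.

From the compounds shown here alone, both ring-bearing compounds carry trifluoromethyl, so its share in the lower numbers stays open, as does the separate share of the thiazole ring. A thiazole bearing methyl, chlorine or an amine instead of trifluoromethyl would address both questions.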